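The compounds below may be only part of what the source reports. "The series", "measured", "known", "first", "only" and "open" are said of these compounds alone.

For the measured compounds named here, compound 1 `COC(=O)CCCCCCCCn1nc(-c2ccccc2)c(-c2ccccc2)c1-c1ccccc1` is the one member of this small set with a numerical result: in a functional assay for inhibition, with Homo sapiens as the target (on this read-out higher numbers stand for weaker inhibition and lower numbers for stronger inhibition), compound 1 gives 4300 nM. Compound 2 `O=C(O)CCCCCn1nc(-c2ccccc2)c(-c2ccccc2)c1-c1ccccc1` reaches only a limit of the assay, > 78000 nM, rather than a number. Compound 3 `CNC(=O)CCCCCCCCn1nc(-c2ccccc2)c(-c2ccccc2)c1-c1ccccc1` likewise stops at a limit, > 68000 nM. Compound 4 `c1ccc(-c2nn(CCCCCCCCc3nnn[nH]3)c(-c3ccccc3)c2-c2ccccc2)cc1` has not yet been tested. It differs from compound 1 in one place: 1H-tetrazol-5-yl in place of methoxycarbonyl on a saturated chain carbon, eight bonds along the chain from an aromatic nitrogen. Going by the values given here, two measured steps bear on this. Putting carboxy in place of 3-(methoxycarbonyl)propyl gave an at least 18-fold higher number from compound 1 to compound 2 (1.25 log units; beyond the scatter), and putting methylamino in place of methoxy on the carbonyl carbon gave an at least 15-fold higher number from compound 1 to compound 3 (1.19 log units; beyond the scatter). The step that the two limits leave unreadable from compound 2 to compound 3 cannot be read, since both compounds sit at limits. Every change away from methoxycarbonyl seen so far has cost a large amount of inhibition, and the tetrazole change removes that same group, so a sizeable move toward weaker inhibition is expected for compound 4 as well, a 7.0-fold higher number from compound 1 to compound 4 (0.84 log units; beyond the scatter). Compound 4 is therefore estimated at 30000 nM, with a plausible range from 6000 nM to 120000 nM, and a real chance that this assay once more reports only a limit rather than a number.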

Compound 4, half-maximal inhibitory concentration: 1040 nM
Beside the measured number, compound 4's estimate is 29-fold (1.46 log units) above it; measured number below the stated range.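

In this assay, the position eight bonds along the chain from an aromatic nitrogen turns out to tolerate more than methoxycarbonyl, since 1H-tetrazol-5-yl there gives a 4.1-fold lower number from compound 1 to compound 4 (0.62 log units; beyond the scatter). For the compounds shown here, this is the first replacement of the ester end of compound 1 that strengthens inhibition instead of weakening it, so compound 4 goes against the losses seen with compound 2 and compound 3. The other two new steps, an at least 65-fold lower number from compound 3 to compound 4 (1.81 log units; beyond the scatter) and an at least 75-fold lower number from compound 2 to compound 4 (1.87 log units; beyond the scatter), are both large, but compound 2 and compound 3 each gave only a limit of the assay and not a number, so these steps show a minimum size and not a true one.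

Still open, on these data alone, is whether a carboxylic acid at this same position, eight bonds along the chain from an aromatic nitrogen, would match 1H-tetrazol-5-yl, and whether a shorter chain would keep the tetrazole's result, as compound 2 differs from compound 4 in both chain and end group. The data shown offer no explanation for the gain seen with compound 4.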